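The source may hold more compounds than are shown below. What is called first, only, known or untested is meant among the compounds shown, and "the series" means these compounds.

Among the measured compounds shown here, only two compounds have been tested so far in a functional assay (Platelet, plasma) for inhibition, with Homo sapiens as the target; on this read-out higher numbers stand for weaker inhibition and lower numbers for stronger inhibition. For compound 1 `CC1OC(=O)c2cc(C#N)c(N3CC(C(=O)NS(=O)(=O)Cc4ccccc4)C3)nc21` the result is > 300000 nM, which is a limit of the assay and not a number. For the measured compounds named here, compound 2 `N#Cc1cc2c(nc1N1CCC(C(=O)NS(=O)(=O)Cc3ccccc3)CC1)CCCC2=O` gives 117000 nM, the only actual number available. Compound 3 `N#Cc1cc2c(nc1N1CCC(C(=O)NS(=O)(=O)Cc3ccccc3)CC1)CCC(F)C2=O` differs from compound 2 in a single place: fluoro in place of hydrogen on a saturated ring carbon, with fluoro in place of hydrogen on a saturated ring carbon. Going by the values given here, no measured pair shows what a change like this does here, so the starting point is simply compound 2 at 117000 nM, and no shift beyond the usual scatter is expected in either direction. The estimated 1.2-fold lower number from compound 2 to compound 3 (0.07 log units; within the scatter) is therefore small. For compound 3 the expected value in this assay is 100000 nM, with an estimated range of 40000 nM to 250000 nM.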

Compound 3, half-maximal inhibitory concentration: 255000 nM
Compound 3: middle estimate off by 2.6-fold (0.41 log units), on the low side; measured number above the stated range.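

In this assay, fluoro in place of hydrogen on a saturated ring carbon gives a 2.2-fold higher number from compound 2 to compound 3 (0.34 log units; beyond the scatter), so this carbon of the six-membered non-aromatic ring is sensitive to a change of a single atom, and here the change goes towards weaker inhibition. Among the compounds shown here, the step is modest, but it is the first measured step between two compounds that differ in one place, and it starts from an already weak compound. There is little room left at this end of the read-out, where compound 1 stands at a limit of the assay and not a number: the limit of > 300000 nM in this assay, at which 1 of the 3 values shown sits.

Going by these compounds, it remains open whether this shift is particular to fluoro or would appear with any group on this carbon. A methyl or a hydroxyl group in the same place would help to tell these two readings apart.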